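The source may report more compounds than this note shows. Statements on the series, on what has been measured and on what is new or still open speak of the compounds shown alone.

Compound 2, `CC(C(=O)NCc1ccc(C(C)(C)C)nc1N1CCCCCC1)c1ccc(NS(C)(=O)=O)c(F)c1`, gives 0.9 nM in an assay on cells for antagonist activity at transient receptor potential cation channel subfamily V member 1 (Homo sapiens), read by FLIPR and calcium flux, with a stated time of 6 min (on this read-out lower numbers stand for stronger inhibition and higher numbers for weaker inhibition), the second highest of the three numbers in hand. Compound 1, `CCCN(CCC)c1nc(C(C)(C)C)ccc1CNC(=O)C(C)c1ccc(NS(C)(=O)=O)c(F)c1`, gives 2.5 nM, and compound 3, `CCC1CCN(c2nc(C(C)(C)C)ccc2CNC(=O)C(C)c2ccc(NS(C)(=O)=O)c(F)c2)CC1`, gives 0.1 nM. Compound 4, `CC(C)Oc1nc(C(C)(C)C)ccc1CNC(=O)C(C)c1ccc(NS(C)(=O)=O)c(F)c1`, carries isopropoxy in place of azepan-1-yl on an aromatic carbon. The measured steps all vary this same position among amino groups: a 2.8-fold lower number from compound 1 to compound 2 (0.44 log units; beyond the scatter), a 9.0-fold lower number from compound 2 to compound 3 (0.95 log units; beyond the scatter) and a 25-fold lower number from compound 1 to compound 3 (1.40 log units; beyond the scatter). None of them swaps a ring amine for an alkoxy group, so they show only that this position moves the read-out strongly, not which way an isopropoxy goes. A smaller, ring-less group here is expected to give a higher number, with wide uncertainty. Compound 4 is therefore estimated at 5 nM, within 1 nM to 25 nM, a step of a 5.6-fold higher number from compound 2 to compound 4 (0.74 log units; beyond the scatter).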

Compound 4, inhibition constant: 2.3 nM
The estimate for compound 4 lay 2.2-fold (0.34 log units) above the measured number, within the range that was stated.
By their numbers in this assay, from the lowest: compound 3; then compound 2; then compounds 4 and 1 (each within the scatter of the next).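

In this assay, replacing azepan-1-yl with isopropoxy gives a 2.6-fold higher number from compound 2 to compound 4 (0.41 log units; beyond the scatter), and replacing 4-ethylpiperidin-1-yl with it gives a 23-fold higher number from compound 3 to compound 4 (1.36 log units; beyond the scatter). Replacing dipropylamino with isopropoxy gives a 1.1-fold lower number from compound 1 to compound 4 (0.04 log units; within the scatter), so the ring-less amine and the ring-less alkoxy group cannot be separated here. Among these four compounds, the two ring amines give the lower numbers, whether the ring-less group is joined through nitrogen or oxygen. Nothing available explains these differences. From the compounds shown here alone, whether a cyclohexyloxy group would match the ring amines or stay with isopropoxy remains open.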